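A Methyl Added to a Noncytotoxic Compound

The compounds below may be only part of what the source reports. "The series", "measured", "known", "first", "only" and "open" are said of these compounds alone.

In an ADME assay on MRC5 cells (Homo sapiens) for cytotoxicity, read by resazurin assay, with a stated time of 72 h (a lower number here means a stronger inhibitor, a higher number a weaker inhibitor), three compounds have been measured:
Compound 1 `CC1(COc2ccc(-c3ccc(F)cc3)cc2)CCn2cc([N+](=O)[O-])nc2O1` gives > 64000 nM as a limit
Compound 2 `O=[N+]([O-])c1cn2c(n1)OC(COc1ccc(-c3ccc(F)nc3)cc1)CC2` gives > 64000 nM as a limit
Compound 3 `CC1(COc2cccc(-c3ccc(F)nc3)n2)CCn2cc([N+](=O)[O-])nc2O1` gives > 64000 nM as a limit

None of these entries is a number, and the evidence so far is the limit of > 64000 nM in this assay, at which 3 of the 3 values shown sit, and nothing finer. Compound 2 gives > 64000 nM and so has a known place only as a limit. Compound 4 `CC1(COc2ccc(-c3ccc(F)nc3)cc2)CCn2cc([N+](=O)[O-])nc2O1` differs from compound 2 in one place (methyl in place of hydrogen on a saturated ring carbon) with methyl in place of hydrogen on a saturated ring carbon, next to the ring oxygen. For the measured compounds named here, no step between two measured compounds is available. Compound 1 carries a methyl on that same saturated ring carbon and gives > 64000 nM as a limit. Compound 3 carries it too and gives > 64000 nM as a limit. In this assay no change beyond the scatter is therefore expected. The expected step (a number no higher from compound 2 to compound 4 (the limit leaves the size open)) is estimated to lie within the scatter. For compound 4 the estimated value is 64000 nM with an expected range from 30000 nM to 100000 nM and a report as a limit is the likeliest outcome.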

Compound 4, half-maximal inhibitory concentration: > 64000 nM
Compound 4 ended at the assay's limit (the forecaster's own chance of this, stated with the estimate: 85%); the middle value sits exactly at the limit.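

No step can be read from compound 2 to compound 4 or from compound 1 to compound 4, since each pair gives only limits: the limit of > 64000 nM in this assay, at which 4 of the 4 values shown sit.

The compounds shown leave open whether methyl in place of hydrogen, or 6-fluoropyridin-3-yl in place of 4-fluorophenyl, changes the read-out at all.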